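Aryl pyrazole diamines: fluoro to methyl on the aryl ring

The source may report more compounds than this note shows. Statements on the series, on what has been measured and on what is new or still open speak of the compounds shown alone.

Of the compounds shown here, three have been tested in an assay on isolated protein for binding affinity to 5-hydroxytryptamine receptor 1E (Homo sapiens); a higher number here means a weaker inhibitor, a lower number a stronger inhibitor. Compound 1 `Cc1cccc(-c2n[nH]cc2N2CCCNCC2)c1` returns in this assay only the limit > 10000 nM, not a number. Compound 2 `Fc1cccc(-c2n[nH]cc2N2CCCNCC2)c1` likewise stops at the limit > 10000 nM in this assay. Compound 3 `Fc1ccc(-c2n[nH]cc2N2CCNCC2)cc1` also gives the limit > 10000 nM in this assay. Going by the values given here, every value so far rests on (the limit of > 10000 nM in this assay, at which 3 of the 3 values shown sit). The difference between the core of compound 2 and the core of compound 3 is not broken down here.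

From compound 2 to compound 1 the change is methyl in place of fluoro on an aromatic carbon, and the two limits give a step that the two limits leave unreadable from compound 2 to compound 1. Compound 4 `Cc1ccc(-c2n[nH]cc2N2CCNCC2)cc1` is not yet measured; it arises from compound 3 by the same kind of change, (methyl in place of fluoro on an aromatic carbon), though here the place is para to a large group rather than meta to it.

Because compound 3 sits at the limit > 10000 nM and the earlier step that the two limits leave unreadable from compound 2 to compound 1 is unreadable, the expected step that the limit leaves unreadable from compound 3 to compound 4 is put at nothing resolvable. Compound 4 is therefore expected at about 20000 nM in this assay, estimated between 5000 nM and 80000 nM, most likely again a limit.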

Compound 4, inhibition constant: > 10000 nM
Compound 4: no number, only a limit; the forecaster's own chance of this, stated with the estimate: 80%; the middle value is on the limit's open side.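

In this assay compound 4 returns only a limit, > 10000 nM, not a number. Compound 3 also stands at a limit, so no step can be read between compound 3 and compound 4 for methyl in place of fluoro. The compounds shown leave open whether any change to this series gives a measurable value in this assay.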